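The source may report more compounds than this note shows. Statements on the series, on what has been measured and on what is new or still open speak of the compounds shown alone.

In an assay on isolated protein for inhibition of hexokinase-2 (Rattus norvegicus), with a stated time of 6 h, tested at 10 mM (a higher number here means more inhibition at the concentration tested (going by the name of the read-out), a lower number less inhibition), compound 1 `CN(CCCCN(C)C(=O)CCCCNc1ncnc2c1ncn2[C@@H]1O[C@H](COP(=O)(O)OP(=O)(O)OP(=O)(O)O)[C@@H](O)[C@H]1O)C(=O)CCCCNC(=O)CI` gives 0%. In this assay compound 2 `Nc1ncnc2c1nc(NCCCCNC(=O)CI)n2[C@@H]1O[C@H](COP(=O)(O)OP(=O)(O)OP(=O)(O)O)[C@@H](O)[C@H]1O` gives 0%. In this assay compound 3 `O=C(CI)NCCCCNc1ncnc2c1ncn2[C@@H]1O[C@H](COP(=O)(O)OP(=O)(O)OP(=O)(O)O)[C@@H](O)[C@H]1O` gives 0%.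

On these numbers compound 3 stands level with compounds 1 and 2 at the digits given; its nearest neighbour is compound 1 and its furthest is compound 2, and to each the difference lies within the scatter. Compound 4 `O=C(CI)NCCCCCCCCNc1ncnc2c1ncn2[C@@H]1O[C@H](COP(=O)(O)OP(=O)(O)OP(=O)(O)O)[C@@H](O)[C@H]1O` has not yet been tested in this assay. It differs from compound 3 by 4-(((iodomethyl)carbonyl)amino)butyl in place of ((iodomethyl)carbonyl)amino on a saturated chain carbon, four bonds along the chain from a nitrogen on an aromatic ring. For the measured compounds named here, no step between measured compounds is available to guide the change, and the three measured values all sit together. The expected step is none beyond the scatter, so the estimate means a step of no change at the digits printed from compound 3 to compound 4 (within the scatter). Compound 4 is expected to give 0%, with a range from 0% to 10%.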

Compound 4, a percentage reported as inhibition, at one concentration (the size of the read-out at that concentration, not a potency): 41%
The estimate for compound 4 lay 41 percentage points below the measured number; the whole stated range lies below it.
By their numbers in this assay, from the lowest: compounds 1, 2 and 3 (each within the scatter of the next); then compound 4.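

this assay records a number 41 percentage points higher from compound 3 to compound 4 (beyond the scatter) when 4-(((iodomethyl)carbonyl)amino)butyl stands in place of ((iodomethyl)carbonyl)amino on a saturated chain carbon, four bonds along the chain from a nitrogen on an aromatic ring. For the compounds shown here, the earlier compounds showed no difference at all, so this is the first sign that the read-out responds to a change at this position. No measurement shown accounts for the step.

On these data alone, whether a longer chain here would raise the number further remains open, as does whether an amine could replace the ((iodomethyl)carbonyl)amino end while keeping the gain.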